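Working notes: trifluoromethyl analogue of compound 3

A few compounds are considered here, and "the series" means these few. Any claim that something is new, unique, unknown or untested is made for them only; others in the source may bear on it.

Measured so far:
compound 1, `O=C1COc2ccc(NC(=O)C3CCN(c4ccccc4Br)CC3)cc2N1`, 160 nM
compound 2, `O=C1COc2ccc(NC(=O)C3CCN(c4ccccc4Cl)CC3)cc2N1`, 220 nM
compound 3, `CC(C)c1ccccc1N1CCC(C(=O)Nc2ccc3c(c2)NC(=O)CO3)CC1`, 180 nM

All three share one core and differ only in the group on the phenyl ring carried by the piperidine nitrogen. In a functional assay for antagonist activity at transient receptor potential cation channel subfamily V member 1 (Homo sapiens), read by FLIPR and calcium flux (a higher number here means a weaker inhibitor, a lower number a stronger inhibitor), the three numbers sit close together: a 1.4-fold higher number from compound 1 to compound 2 (0.14 log units; within the scatter), a 1.1-fold higher number from compound 1 to compound 3 (0.05 log units; within the scatter) and a 1.2-fold lower number from compound 2 to compound 3 (0.09 log units; within the scatter) are each within the scatter, so none of the three can be called stronger or weaker than another. Compound 3 stands second highest of the three numbers, nearest to compound 1 and furthest from compound 2, both gaps within the scatter.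

Compound 4, `O=C1COc2ccc(NC(=O)C3CCN(c4ccccc4C(F)(F)F)CC3)cc2N1`, is the next member. Compared with compound 3 the change is trifluoromethyl in place of isopropyl on an aromatic carbon.

Going by the values given here, no measured step involves a trifluoromethyl group, so there is no direct precedent. What the three steps do show is that bromo, chloro and isopropyl at this position give numbers within the scatter of each other. On that basis the expectation for compound 4 is a step of a 1.1-fold higher number from compound 3 to compound 4 (0.05 log units; within the scatter), that is, no change beyond the scatter in either direction. The estimated value for compound 4 is 200 nM, with a range from 90 nM to 450 nM.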

Compound 4, half-maximal inhibitory concentration: 380 nM
The estimate for compound 4 lay 1.9-fold (0.28 log units) below the measured number, and the stated range covers the measured number.
By their numbers in this assay, from the lowest: compounds 1, 3, 2 and 4 (each within the scatter of the next, the first and the last beyond it).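

In this assay, going by these compounds alone, trifluoromethyl is the first group at this position to separate from any other, giving a higher number than both isopropyl (a 2.1-fold higher number from compound 3 to compound 4 (0.32 log units; beyond the scatter)) and bromo (a 2.4-fold higher number from compound 1 to compound 4 (0.38 log units; beyond the scatter)), so the position is less indifferent to its substituent than the bromo, chloro and isopropyl compounds alone suggested. The separation is only partial and modest in size: against chloro the change stays unresolved (a 1.7-fold higher number from compound 2 to compound 4 (0.24 log units; within the scatter)), so compound 4 cannot be ranked against compound 2, and compound 2 cannot be ranked against compound 1 or compound 3 either. The data shown give no measured property or other information that would explain why trifluoromethyl stands apart from isopropyl and bromo.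

Still open, from the compounds shown here alone, is how this position responds to groups of a different kind, such as an amine, a carboxylic acid, a nitrile or a longer alkyl chain, and whether any of them would move the number further in either direction. Going by these compounds, all four compounds also share one core, so whether the step from isopropyl to trifluoromethyl repeats on a different core remains unknown.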